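Swapping the Amide Substituent in a Series at the Assay Limit

The compounds below may be only part of what the source reports. "The series", "measured", "known", "first", "only" and "open" are said of these compounds alone.

Compound 1 `O=C(/C=C/c1coc2cc(O)ccc2c1=O)NCc1ccccc1`: in a functional assay on HeLa cells (Homo sapiens) for inhibition, read by MTT assay, with a stated time of 48 h (on this read-out lower numbers stand for stronger inhibition and higher numbers for weaker inhibition), compound 1 gives > 100000 nM, which is a limit of the assay and not a number.
Compound 2 `COc1ccc2c(=O)c(/C=C/C(=O)Nc3ccccc3)coc2c1`: in this assay compound 2 gives > 100000 nM, again a limit.
Compound 3 `Cc1ccc(CNC(=O)/C=C/c2coc3cc(O)ccc3c2=O)cc1`: in this assay compound 3 gives > 100000 nM, also a limit.

Compound 3 therefore stands at the limit of this assay, and so do the other two compounds measured, as the summary the limit of > 100000 nM in this assay, at which 3 of the 3 values shown sit, records. Among the measured compounds shown here, the only single-point comparison available, a step that the two limits leave unreadable from compound 1 to compound 3, joins two limits and its size cannot be read.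

Compound 4 `O=C(/C=C/c1coc2cc(O)ccc2c1=O)Nc1ccccc1` is reached from compound 3 by the change (phenyl in place of 4-methylbenzyl on an amide-type nitrogen). For the measured compounds named here, no measured step shows what this exchange does. Compound 2, which carries the same phenyl on its amide-type nitrogen but differs elsewhere, also sits at the limit; by itself that is only a limit, not a sign of a trend.

With every measured value at the limit, no step beyond the scatter can be foreseen for compound 4 in this assay. The estimate for compound 4 is 150000 nM, with a range from 50000 nM to 500000 nM. The expected step that the limit leaves unreadable from compound 3 to compound 4 is therefore essentially none, with a limit again the most likely outcome.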

Compound 4, half-maximal inhibitory concentration: 9700 nM
Beside the measured number, compound 4's estimate is 15-fold (1.19 log units) above it; the whole stated range lies above it.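

In this assay, among the compounds shown here, phenyl in place of 4-methylbenzyl on the amide-type nitrogen gives an at least 10-fold lower number from compound 3 to compound 4 (1.01 log units; beyond the scatter), and phenyl in place of benzyl at the same place gives an at least 10-fold lower number from compound 1 to compound 4 (1.01 log units; beyond the scatter), so this position can carry a readable effect, which the earlier compounds, all at a limit, could not show. Phenyl alone does not account for this, since hydrogen in place of methyl on the oxygen on the aromatic ring gives an at least 10-fold lower number from compound 2 to compound 4 (1.01 log units; beyond the scatter); compound 2 carries the same phenyl and goes against any rule based on that group alone, so among these compounds only the phenyl together with the free hydroxyl gives a number. Each of these steps gives only a minimum size, because the starting value in each pair is a limit: the limit of > 100000 nM in this assay, at which 3 of the 4 values shown sit.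

On these data alone, how far the benzyl and 4-methylbenzyl compounds truly lie from compound 4 stays open, as does the effect of the methyl on the ring, since the step between those two compounds cannot be read. Also open, as far as these compounds go, is whether 4-methylphenyl or a longer chain such as 2-phenylethyl on the amide-type nitrogen would keep this activity.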